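A few compounds are considered here, and "the series" means these few. Any claim that something is new, unique, unknown or untested is made for them only; others in the source may bear on it.

In a functional assay on the whole organism (strain albino) with Mus musculus as the target, in the maximal electroshock model, with a stated time of 0.5 h (a higher number here means that more compound is needed for the effect, a lower number that less compound is needed), compound 1, whose structure is `O=[N+]([O-])c1ccc(-c2csc(Nc3nnc(Nc4ccccc4)s3)n2)cc1`, gives 100 mg/kg. Compound 2, with the structure `COc1ccccc1Nc1nnc(Nc2nc(-c3ccccc3)cs2)s1`, gives in this assay a minimum effective dose of 100 mg/kg, level with compound 1 at the digits reported and within the usual scatter of the method. The two compounds share a core and differ only in what stands on the outer aromatic ring, yet this difference does not appear as a step in the numbers.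

Compound 3, with the structure `c1ccc(Nc2nnc(Nc3nc(-c4ccccc4)cs3)s2)cc1`, is the next compound to be examined. It differs from compound 2 in one place: hydrogen in place of methoxy on an aromatic carbon.

Among the compounds with values here, no step between two measured compounds is available to anchor this change. Since compound 1 and compound 2 sit together in this assay, the step from compound 2 to compound 3 is expected to be small, no change at the digits printed from compound 2 to compound 3 (within the scatter), in no direction beyond the scatter. Compound 3 is therefore estimated to give 100 mg/kg in this assay, with a range from 50 mg/kg to 200 mg/kg.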

Compound 3, minimum effective dose: 300 mg/kg
The estimate for compound 3 lay 3.0-fold (0.48 log units) below the measured number; the whole stated range lies below it.
By their numbers in this assay, from the lowest: compounds 1 and 2 (each within the scatter of the next); then compound 3.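

In this assay the change from 2-methoxyphenyl to phenyl gives a 3.0-fold higher number from compound 2 to compound 3 (0.48 log units; beyond the scatter), so this position, on an aromatic carbon ortho to a large group, does register in the numbers: with hydrogen there, more compound is needed. Hydrogen in place of nitro on an aromatic carbon gives a 3.0-fold higher number from compound 1 to compound 3 (0.48 log units; beyond the scatter), which shows that a change at a second place in the molecule also yields a step beyond the scatter and leaves compound 3, which carries neither group, needing the most compound of the three. Nothing at hand explains why either group lowers the dose needed.

Going by these compounds, it remains open whether an amine, a chlorine atom or a longer alkoxy chain at this position would match methoxy. Also open, on these data alone, is whether methoxy elsewhere on that ring would give the same step, and whether methoxy and nitro together would lower the number further.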